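The source may report more compounds than this note shows. Statements on the series, on what has been measured and on what is new or still open speak of the compounds shown alone.

Of the compounds shown here, three carrying the same shared core have been measured in a functional assay on PC-3 cells (Homo sapiens) for inhibition, read by sulforhodamine B assay, with a stated time of 48 h; on this read-out lower numbers stand for stronger inhibition and higher numbers for weaker inhibition. Compound 1 `O=C(Nc1cccc(-n2cc(-c3ccncc3)c(-c3ccc(Cl)c(O)c3)n2)c1)Nc1cccc(C(F)(F)F)c1` gives 950 nM. Compound 2 `O=C(Nc1cccc(-n2cc(-c3ccncc3)c(-c3ccc(Cl)c(O)c3)n2)c1)Nc1ccc(Cl)c(Cl)c1` gives 830 nM. Compound 3 `COc1cc(-c2nn(-c3cccc(NC(=O)Nc4ccc(Cl)c(C(F)(F)F)c4)c3)cc2-c2ccncc2)ccc1Cl` gives 690 nM. Compound 3 stands at the lowest of the three numbers, but its distance to compound 2 and to compound 1 is within the scatter, so no order among the three can be read from these numbers.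

The next compound, compound 4 `O=C(Nc1cccc(-n2cc(-c3ccncc3)c(-c3ccc(Cl)c(O)c3)n2)c1)Nc1ccc(Cl)c(C(F)(F)F)c1`, differs from compound 3 by hydrogen in place of methyl on an oxygen on an aromatic ring, which amounts to methoxy to hydroxy on the ring that carries the chloro substituent. Among the compounds with values here, only one step between measured compounds is available, a 1.1-fold lower number from compound 1 to compound 2 (0.06 log units; within the scatter), and it concerns the aryl group on the urea, not the oxygen substituent. Within the data shown here, no measured pair isolates the exchange of methoxy for hydroxy, so the expectation for compound 4 rests on the narrow spread of all three numbers. Compound 1 and compound 2 both carry the hydroxy group, and their values sit close to that of compound 3 with methoxy.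

Compound 4 is therefore expected to show a step of a 1.2-fold higher number from compound 3 to compound 4 (0.09 log units; within the scatter) that does not go beyond the scatter, with an estimated value of 850 nM and a range from 400 nM to 1800 nM in this assay.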

Compound 4, half-maximal inhibitory concentration: 590 nM
The estimate for compound 4 lay 1.4-fold (0.16 log units) above the measured number; low and high end bracket the measured number.
By their numbers in this assay, from the lowest: compounds 4, 3, 2 and 1 (each within the scatter of the next).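

Read directly in this assay, the change from 4-chloro-3-methoxyphenyl to 4-chloro-3-hydroxyphenyl, with hydrogen in place of methyl on an oxygen on an aromatic ring, gives a 1.2-fold lower number from compound 3 to compound 4 (0.07 log units; within the scatter) and so leaves the number at this position within the scatter. Compound 4 also ties this position to the aryl group on the urea of the earlier hydroxy compounds, where trifluoromethyl in place of chloro on an aromatic carbon gives a 1.4-fold lower number from compound 2 to compound 4 (0.15 log units; within the scatter) and chloro in place of hydrogen on an aromatic carbon gives a 1.6-fold lower number from compound 1 to compound 4 (0.21 log units; within the scatter), so neither of these changes shows a difference beyond the scatter. Nothing available here bears on why these steps are so small.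

The compounds shown carry only hydroxy or methoxy on this ring, so it stays open whether an amine, a carboxylic acid or a longer chain such as ethoxy in that place would stay within the same range. Going by these compounds, it also stays open how a nitrile on the aryl group of the urea would read in this assay.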